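Swapping the saturated ring on a weakly cytotoxic triazine

The compounds below may be only part of what the source reports. "The series", "measured", "known", "first", "only" and "open" are said of these compounds alone.

Measured compounds:
compound 1 `CC1CC(C)CN(c2nc(Nc3ccc(C#N)c(C(F)(F)F)c3)nc(Oc3ccnc4ccccc34)n2)C1`: 27200 nM
compound 2 `N#Cc1ccc(Nc2nc(Oc3ccnc4ccccc34)nc(N3CCC(Cc4ccccc4)CC3)n2)cc1C(F)(F)F`: > 100000 nM

Of the compounds shown here, two sharing one core have been tested in a functional assay on DU-145 cells (Homo sapiens) for cytotoxicity, read by sulforhodamine B assay, with a stated time of 48 h; a lower number here means a stronger inhibitor of growth, a higher number a weaker inhibitor of growth. Within the data shown here, compound 1 gives 27200 nM, the only value that is an actual number here. Compound 2 reaches only the limit of the assay, > 100000 nM, and no number beyond that is known; this is the limit of > 100000 nM in this assay, at which 1 of the 2 values shown sits. Compound 1 therefore stands as the single measured point, with compound 2 above the reach of the assay.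

Compound 3 `N#Cc1ccc(Nc2nc(Oc3ccnc4ccccc34)nc(N3CCN(c4ccccn4)CC3)n2)cc1C(F)(F)F` is not yet measured. It differs from compound 1 in one place: 4-(pyridin-2-yl)piperazin-1-yl in place of 3,5-dimethylpiperidin-1-yl on an aromatic carbon. Among the measured compounds shown here, no measured step links a pair of compounds, so nothing shows how this assay answers to a change at this place; compound 1 itself is already a weak growth inhibitor. The expected step from compound 1 to compound 3 is a 1.7-fold higher number from compound 1 to compound 3 (0.22 log units; within the scatter), toward weaker inhibition or no change beyond the scatter. Compound 3 is expected to give about 45000 nM, within the range from 12000 nM to 100000 nM.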

Compound 3, concentration for 50% growth inhibition: 85900 nM
Estimate against measurement, compound 3: 1.9-fold (0.28 log units) below; the measured number falls inside the stated range.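

Among these compounds, this is the first step that can be read at this place, on the aromatic carbon between two ring nitrogen atoms: in this assay there is a 3.2-fold higher number from compound 1 to compound 3 (0.50 log units; beyond the scatter) when 4-(pyridin-2-yl)piperazin-1-yl replaces 3,5-dimethylpiperidin-1-yl. Growth inhibition therefore does answer to the group here, although the move is modest and runs toward weaker inhibition from a compound that was already weak. Among the compounds shown here, compound 2 remains a limit rather than a number, so it gives no size for a step at this place: the limit of > 100000 nM in this assay, at which 1 of the 3 values shown sits.

This single swap changes the saturated ring and adds the pyridine together, so the compounds shown do not tell which part goes with the step. From the compounds shown here alone, whether a morpholin-4-yl group or a plain dimethylamino group at this place would give stronger inhibition than compound 1 also remains open.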